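One Change Repeated Across Two Cores, One Expectation

The source may report more compounds than this note shows. Statements on the series, on what has been measured and on what is new or still open speak of the compounds shown alone.

Compound 1 `CS/C(=N\C(=O)c1csc([N+](=O)[O-])c1)NC(=O)c1csc([N+](=O)[O-])c1`: 21400 nM
Compound 2 `CS/C(=N\C(=O)c1ccco1)NC(=O)c1ccco1`: 46500 nM
Compound 3 `O=C(/N=C(/NC(=O)c1ccco1)[Se]Cc1ccccc1)c1ccco1`: 58000 nM

All three were measured in an ADME assay on MCF-10A cells (Homo sapiens) for cytotoxicity, read by MTT assay, with a stated time of 72 h; a lower number here means a stronger inhibitor of growth, a higher number a weaker inhibitor of growth. In this assay compound 1 gives 21400 nM, compound 2 gives 46500 nM and compound 3 gives 58000 nM. Compound 1 stands lowest of the three, and its steps to both of the others are beyond the scatter.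

Compound 2 and compound 3 share a core and differ in one place: a group of 8 heavy atoms (7 carbon, 1 selenium; one six-membered aromatic ring of carbon only) in place of a group of 2 heavy atoms (1 carbon, 1 sulfur; no ring), on a carbon with a double bond to nitrogen. That change made a 1.2-fold higher number from compound 2 to compound 3 (0.10 log units; within the scatter), so the two values cannot be told apart.

Compound 1 has a different core from compound 2; how the two cores differ is not broken down here.

Compound 4 `O=C(/N=C(/NC(=O)c1csc([N+](=O)[O-])c1)[Se]Cc1ccccc1)c1csc([N+](=O)[O-])c1` has not been measured. It relates to compound 1 exactly as compound 3 relates to compound 2: a group of 8 heavy atoms (7 carbon, 1 selenium; one six-membered aromatic ring of carbon only) in place of a group of 2 heavy atoms (1 carbon, 1 sulfur; no ring), on a carbon with a double bond to nitrogen. The place is described in the same words for both pairs, so this is the same change, seen here twice in all.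

Because a 1.2-fold higher number from compound 2 to compound 3 (0.10 log units; within the scatter) was within the scatter, the expectation for the step from compound 1 to compound 4 is a similarly small one, a 1.2-fold higher number from compound 1 to compound 4 (0.07 log units; within the scatter), set beside the earlier step. This rests on a single measured pair, so the range is kept wide. Compound 4 is therefore estimated at 25000 nM, with an expected span from 12000 nM to 52000 nM.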

Compound 4, concentration for total growth inhibition: 54100 nM
Compound 4: middle estimate off by 2.2-fold (0.34 log units), on the low side, outside the stated range (above it).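

On the core of compound 1, putting the larger selenium-bearing group with its six-membered aromatic ring in place of methylsulfanyl, on the carbon with a double bond to nitrogen, gave a 2.5-fold higher number from compound 1 to compound 4 (0.40 log units; beyond the scatter) in this assay. This step is clear on its own, unlike the step on the other core, but the real test is how far apart the two steps lie, and that gap does not exceed what repeated measurements could produce: the same change on two cores in this assay, a 1.2-fold higher number (0.10 log units; within the scatter) from compound 2 to compound 3 and a 2.5-fold higher number (0.40 log units; beyond the scatter) from compound 1 to compound 4, 2.0-fold (0.31 log units) apart, within the scatter of two such steps. The result therefore shows no firm difference in how the change behaves on the two cores, but it does not prove that the change carries over unaltered, and two pairs are too few to set a rule for this series.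

The compounds shown leave open which part of the entering group goes with the step on the core of compound 1, the selenium or the aromatic ring; a benzylsulfanyl group or a methylselanyl group at the same carbon would pull these two apart. They also leave open what a quite different group there, such as an amine or a longer alkyl chain, would do on either core.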